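Replacing an alkyl-bearing phenyl with a bromophenyl in a diaryl urea

The source may hold more compounds than are shown below. What is called first, only, known or untested is meant among the compounds shown, and "the series" means these compounds.

This account concerns a set of diaryl ureas tested in a functional assay on HepG2 cells (Homo sapiens) for inhibition, read by MTT assay, with a stated time of 72 h; on this read-out higher numbers stand for weaker inhibition and lower numbers for stronger inhibition. Compound 1 `CCc1cccc(-n2cc(COc3cccc(NC(=O)Nc4ccc(Cl)c(C(F)(F)F)c4)c3)nn2)c1` gives 37900 nM and stands highest of the three numbers, so it is the weakest inhibitor of the group. Compound 2 `CC(C)c1cccc(-n2cc(COc3cccc(NC(=O)Nc4ccc(Cl)c(C(F)(F)F)c4)c3)nn2)c1` gives 3250 nM, and compound 3 `O=C(Nc1cccc(OCc2cn(-c3cccc(Cl)c3)nn2)c1)Nc1ccc(Cl)c(C(F)(F)F)c1` gives 2020 nM; between these two the difference is a 1.6-fold lower number from compound 2 to compound 3 (0.21 log units; within the scatter).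

Compound 4 `O=C(Nc1cccc(OCc2cn(-c3ccc(Br)cc3)nn2)c1)Nc1ccc(Cl)c(C(F)(F)F)c1` has not yet been measured. It differs from compound 1 in one place: 4-bromophenyl in place of 3-ethylphenyl on an aromatic nitrogen. Among the measured compounds shown here, two measured steps bear on this change. Enlarging the chain on the phenyl brought a 12-fold lower number from compound 1 to compound 2 (1.07 log units; beyond the scatter), and exchanging that chain for chloro brought a 19-fold lower number from compound 1 to compound 3 (1.27 log units; beyond the scatter). For the measured compounds named here, both steps start from compound 1 and both lower the number by a large margin, which suggests that the group on this phenyl is a sensitive place, although no measured compound carries a group at the same position on the ring as compound 4, so the present case is not directly covered.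

On this basis the author expects compound 4 to follow compound 3 more closely than compound 1, with an estimated step of a 13-fold lower number from compound 1 to compound 4 (1.10 log units; beyond the scatter), giving an expected value of 3000 nM within a range of 800 nM to 12000 nM.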

Compound 4, half-maximal inhibitory concentration: 2730 nM
Compound 4: middle estimate off by 1.1-fold (0.04 log units), on the high side; the measured number falls inside the stated range.
By their numbers in this assay, from the lowest: compounds 3, 4 and 2 (each within the scatter of the next); then compound 1.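

In this assay, the change to 4-bromophenyl gives a 14-fold lower number from compound 1 to compound 4 (1.14 log units; beyond the scatter), which makes this the third replacement on the aromatic nitrogen to stand clearly apart from the 3-ethylphenyl of compound 1. The new group also extends the comparison to a substituent at a different ring position, yet it shows a 1.4-fold higher number from compound 3 to compound 4 (0.13 log units; within the scatter) and a 1.2-fold lower number from compound 2 to compound 4 (0.08 log units; within the scatter), so compounds 2, 3 and 4 cannot be told apart despite carrying 3-isopropylphenyl, 3-chlorophenyl and 4-bromophenyl; among these four compounds, the separation therefore does not follow a simple division into alkyl and halogen groups, as compound 2 carries an alkyl group and remains with the two halogen-bearing compounds. No measurement at hand explains why 3-ethylphenyl alone stands apart.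

The halogen and its ring position change together from 3-chlorophenyl to 4-bromophenyl, so the contribution of each remains unresolved. Going by these compounds, it also remains open how this assay would respond to an amine or a carboxylic acid on this phenyl, or to a longer chain than ethyl or isopropyl.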